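Swapping the sulfonyl aryl group on a shared core

The source may report more compounds than this note shows. Statements on the series, on what has been measured and on what is new or still open speak of the compounds shown alone.

Compound 3: `CC1CCN(c2c(S(=O)(=O)c3cc(F)cc(F)c3)cnc3cc(Cl)ccc23)CC1`, 94%
Compound 1: `COc1ccc(S(=O)(=O)c2cnc3cc(Cl)ccc3c2N2CCC(C)CC2)cc1Cl`, 93%
Compound 2: `CC1CCN(c2c(S(=O)(=O)c3ccc(F)cc3)cnc3ccc(F)cc23)CC1`, 87%

Three compounds sharing one core were measured in an assay on isolated protein for displacement of a labelled ligand from metabotropic glutamate receptor 5 (Homo sapiens), with a stated time of 60 min, tested at 1 uM; on this read-out higher numbers stand for more inhibition at the one concentration tested (going by the name of the read-out) and lower numbers for less inhibition. Compound 3 gives the top number of the three, yet compound 1, with 93%, and compound 2, with 87%, both sit within the scatter of it, so the three cannot be set in any order.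

Compound 4, `COc1ccc(S(=O)(=O)c2cnc3cc(Cl)ccc3c2N2CCC(C)CC2)cc1`, is not yet measured. Compared with compound 3 it carries 4-methoxyphenyl in place of 3,5-difluorophenyl on a sulfonyl sulfur. Going by the values given here, the only measured step at this same place is a number 1 percentage points higher from compound 1 to compound 3 (within the scatter), which was within the scatter. Compound 2 differs from compound 3 in more than one place, and its value stands within the scatter of compound 3 as well. With every change at the sulfonyl aryl group so far leaving the read-out close to unchanged, no step beyond the scatter is expected for compound 4 in this assay, and the expected step of a number 4 percentage points lower from compound 3 to compound 4 (within the scatter) is small. The estimate for compound 4 is 90%, with a range from 78% to 97%.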

Compound 4, a percentage reported as inhibition, at one concentration (the size of the read-out at that concentration, not a potency): 79%
Compound 4: middle estimate off by 11 percentage points, on the high side; low and high end bracket the measured number.
By their numbers in this assay, from the lowest: compounds 4, 2, 1 and 3 (each within the scatter of the next, the first and the last beyond it).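

Going by these compounds alone, the sulfonyl aryl group is less free to change than the pair compound 1 and compound 3 suggested: in this assay, 4-methoxyphenyl in place of 3,5-difluorophenyl on a sulfonyl sulfur gives a number 15 percentage points lower from compound 3 to compound 4 (beyond the scatter) and is the only step at this place beyond the scatter. A single atom on that aryl group also matters, as hydrogen in place of chloro on an aromatic carbon gives a number 14 percentage points lower from compound 1 to compound 4 (beyond the scatter) and so a methoxy-bearing aryl group alone does not keep the number high. No measurement shown here accounts for either step.

As far as these compounds go, compound 4 brings in the methoxy group and loses both fluorines in one change, so which of these matters stays open. An unsubstituted phenyl, or a phenyl carrying an amine or a nitrile, would help to separate the two.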